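This account rests on a few compounds, and the source may have more. Where it says the series, first, only, none or still open, it means among the compounds named here.

Compound 1 `Cc1cccc(CS(=O)(=O)n2c(=O)[nH]c3ccc(Cl)cc32)c1` and compound 2 `Cc1ccc(CS(=O)(=O)n2c(=O)[nH]c3ccc(Cl)cc32)cc1` carry the methylphenyl group on a saturated chain carbon bound to a sulfonyl sulfur; compound 3 `Cc1cccc(CCS(=O)(=O)n2c(=O)[nH]c3ccc(Cl)cc32)c1` and compound 4 `Cc1ccc(CCS(=O)(=O)n2c(=O)[nH]c3ccc(Cl)cc32)cc1` carry it two bonds along the chain from a sulfonyl sulfur. In an ADME assay on MT4 cells (Homo sapiens) for cytotoxicity, read by MTT assay, with a stated time of 5 days (on this read-out lower numbers stand for higher toxicity in this test and higher numbers for lower toxicity in this test), compound 1 gives 110000 nM and compound 2 gives 93000 nM. The change between them, (4-methylphenyl in place of 3-methylphenyl on a saturated chain carbon bound to a sulfonyl sulfur), made a step of a 1.2-fold lower number from compound 1 to compound 2 (0.07 log units; within the scatter). In this assay compound 3 gives 31000 nM, the lowest of the three numbers, and its steps to both other compounds lie beyond the scatter. How the core of compound 3 differs from the core of compound 1 is not broken down here. Compound 4 differs from compound 3 by 4-methylphenyl in place of 3-methylphenyl on a saturated chain carbon, two bonds along the chain from a sulfonyl sulfur. This is the same kind of change as from compound 1 to compound 2, but the place is not the same: there the group sits on a saturated chain carbon bound to a sulfonyl sulfur, here on a saturated chain carbon two bonds along the chain from a sulfonyl sulfur. Because the earlier step of a 1.2-fold lower number from compound 1 to compound 2 (0.07 log units; within the scatter) stayed within the scatter, the step from compound 3 to compound 4 is expected to be small as well, a 1.1-fold lower number from compound 3 to compound 4 (0.06 log units; within the scatter). Compound 4 is estimated at 27000 nM, with a likely range from 12000 nM to 65000 nM.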

Compound 4, half-maximal cytotoxic concentration: 161000 nM
The estimate for compound 4 lay 6.0-fold (0.78 log units) below the measured number; the whole stated range lies below it.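

On the core of compound 3, the change from 3-methylphenyl to 4-methylphenyl gives a 5.2-fold higher number from compound 3 to compound 4 (0.72 log units; beyond the scatter), so in this assay the 4-methylphenyl compound on this core reads as the less toxic of the pair. The step on the core of compound 1 does not predict the step on the core of compound 3, and this change cannot be carried from one core to the other at a fixed size: the same change on two cores in this assay, a 1.2-fold lower number (0.07 log units; within the scatter) from compound 1 to compound 2 and a 5.2-fold higher number (0.72 log units; beyond the scatter) from compound 3 to compound 4, 6.1-fold (0.79 log units) apart, beyond the scatter of two such steps This rests on one pair per core, so it shows that the outcome of this change depends on the core in these four compounds, but it gives neither a cause nor a rule for any other core.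

Still open, from the compounds shown here alone, is how this assay would read with a longer chain on the sulfonyl sulfur. Also open, going by these compounds, is whether the same dependence on the core would appear if an amine or a carboxylic acid took the place of the methyl group on the phenyl ring.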